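Methylamino to 2,6-dimethylmorpholin-4-yl on a carbonyl carbon

The source may report more compounds than this note shows. Statements on the series, on what has been measured and on what is new or still open speak of the compounds shown alone.

Compound 1 `C/C(=C\c1ccc(NC(=O)Nc2ccc(Cl)c(C(F)(F)F)c2)cc1)C(=O)NC(C)c1ccccc1` gives > 50000 nM as a limit in a functional assay on A-375 cells (Homo sapiens) for inhibition, read by MTT assay, with a stated time of 120 h; a higher number here means a weaker inhibitor, a lower number a stronger inhibitor
Compound 2 `CNC(=O)/C(C)=C/c1ccc(NC(=O)Nc2ccc(Cl)c(C(F)(F)F)c2)cc1` gives > 50000 nM as a limit in this assay

Compound 2 has no number in this assay, only a limit, and compound 1 stands in the same position. The record so far is the limit of > 50000 nM in this assay, at which 2 of the 2 values shown sit, and gives no measured potency to start from.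

The next compound is compound 3 `C/C(=C\c1ccc(NC(=O)Nc2ccc(Cl)c(C(F)(F)F)c2)cc1)C(=O)N1CC(C)OC(C)C1`, which keeps the core of compound 2. In it, 2,6-dimethylmorpholin-4-yl stands in place of methylamino on a carbonyl carbon 2,6-dimethylmorpholin-4-yl in place of methylamino on a carbonyl carbon and the rest is unchanged.

Among the measured compounds shown here, one measured step bears on this, a change on the same amide-type nitrogen, methyl in place of 1-phenylethyl. That step is a step that the two limits leave unreadable from compound 1 to compound 2 and so offers no size to carry over. Neither of the two amides gave a number, so no clear shift in either direction is expected.

For compound 3 the estimated step is a number no higher from compound 2 to compound 3 (the limit leaves the size open) and it carries little weight. Compound 3 is estimated at 50000 nM with an expected range from 20000 nM to 100000 nM and a report of only a limit is the likeliest outcome.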

Compound 3, half-maximal inhibitory concentration: > 50000 nM
Compound 3 was reported as a limit; the forecaster's own chance of this, stated with the estimate: 70%; the middle value lies on the limit itself.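

In this assay, among the compounds shown here, compound 3 gives > 50000 nM, which is a limit, so no step from compound 1 or compound 2 to compound 3 can be read. The compounds shown leave open whether any of these amide groups on the shared core changes potency in this assay, as the record still stands at one value: the limit of > 50000 nM in this assay, at which 3 of the 3 values shown sit.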